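Swapping the Aryl Ring on a Thiazole-Piperazine Series

The source may hold more compounds than are shown below. What is called first, only, known or untested is meant among the compounds shown, and "the series" means these compounds.

Measured compounds:
- Compound 1, `CCCc1ncc(-c2nc(C(F)(F)F)sc2N2CCN(C(=O)Cn3cnc4cccnc43)[C@H](C)C2)cn1`: 45 nM
- Compound 2, `Cc1nc(C)n(CC(=O)N2CCN(c3sc(C(F)(F)F)nc3-c3cnc(OC(C)C)nc3)C[C@H]2C)n1`: 216 nM
- Compound 3, `CCCc1ncc(-c2nc(C(F)(F)F)sc2N2CCN(C(=O)Cn3nc(C)nc3C)[C@H](C)C2)cn1`: 367 nM

These three compounds were tested in an assay on blood for inhibition of C-X-C chemokine receptor type 3 (Homo sapiens), with a stated time of 30 min; on this read-out higher numbers stand for weaker inhibition and lower numbers for stronger inhibition. Compound 3 gives the highest number of the three; compound 2 lies closest to it, within the usual scatter, while compound 1 gives a clearly lower number, as an 8.2-fold higher number from compound 1 to compound 3 (0.91 log units; beyond the scatter) shows. That step changed the group on the saturated chain carbon bound to the carbonyl carbon. The other measured step, a 1.7-fold higher number from compound 2 to compound 3 (0.23 log units; within the scatter), swapped one substituent on the 2-propylpyrimidin-5-yl group and stayed within the scatter.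

Compound 4, `Cc1nc(C)n(CC(=O)N2CCN(c3sc(C(F)(F)F)nc3-c3ccc(C(F)(F)F)nc3)C[C@H]2C)n1`, has not yet been measured. Its difference from compound 3 is 6-(trifluoromethyl)pyridin-3-yl in place of 2-propylpyrimidin-5-yl on an aromatic carbon. Within the data shown here, no measured step exchanges this whole ring; the nearest precedent, the step from compound 2 to compound 3, touched only a substituent on it and changed little. With no direct guide, no step beyond the scatter is expected here, and the number for compound 4 is estimated to stay near that of compound 3, a 1.1-fold lower number from compound 3 to compound 4 (0.05 log units; within the scatter). The expected value for compound 4 in this assay is 330 nM, with a range from 110 nM to 1000 nM.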

Compound 4, half-maximal inhibitory concentration: 860 nM
The estimate for compound 4 lay 2.6-fold (0.42 log units) below the measured number; low and high end bracket the measured number.
By their numbers in this assay, from the lowest: compound 1; then compounds 2 and 3 (each within the scatter of the next); then compound 4.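

In this assay, replacing the whole aromatic ring on this carbon, next to the ring nitrogen of the shared core, gave a 2.3-fold higher number from compound 3 to compound 4 (0.37 log units; beyond the scatter), and the comparison with the isopropoxy analogue gave a 4.0-fold higher number from compound 2 to compound 4 (0.60 log units; beyond the scatter), both beyond the scatter. The earlier change of substituent on the pyrimidine ring, a 1.7-fold higher number from compound 2 to compound 3 (0.23 log units; within the scatter), stayed within the scatter, so this position tolerated propyl and isopropoxy alike but gave weaker inhibition with 6-(trifluoromethyl)pyridin-3-yl in their place. No measurement is available that explains this loss of inhibition.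

The ring and its substituent change together in this step, so the compounds shown leave open whether the shift follows from the pyridine ring, from the trifluoromethyl group, or from the two in combination; a pyridine ring carrying propyl and a pyrimidine ring carrying trifluoromethyl would separate these two parts. Among these compounds, it also remains open whether the same ring exchange has a similar size when the side chain of compound 1 replaces the one shared by compound 2, compound 3 and compound 4.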